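This account rests on a few compounds, and the source may have more. Where it says the series, first, only, none or still open, it means among the compounds named here.

Measured so far:
Compound 1 `Cc1nc(Nc2ccc(Cl)cc2)sc1C(=O)/C=C/c1ccccc1` — in a functional assay on BGC-823 cells (Homo sapiens) for cytotoxicity, read by MTT assay (a lower number here means a stronger inhibitor, a higher number a weaker inhibitor), compound 1 gives > 25000 nM, a limit of the assay rather than a number.
Compound 2 `COc1cccc(/C=C/C(=O)c2sc(Nc3ccccc3)nc2C)c1` — in this assay compound 2 gives 14300 nM.
Compound 3 `Cc1nc(Nc2ccccc2)sc1C(=O)/C=C/c1ccc(Cl)cc1` — in this assay compound 3 gives > 25000 nM, again a limit.

Compound 3 thus stands only at a limit. Among the measured compounds shown here, of the three values, two sit at the limit of > 25000 nM in this assay, at which 2 of the 3 values shown sit, and the one measured step, an at least 1.7-fold higher number from compound 2 to compound 3 (0.24 log units; that floor lies within the scatter), is itself bounded by that same limit. Compound 4 `Cc1nc(Nc2ccc(Cl)cc2)sc1C(=O)/C=C/c1ccc(Cl)cc1` differs from compound 3 by chloro in place of hydrogen on an aromatic carbon. For the measured compounds named here, no measured step covers this change. Compound 1 carries the same chloro group, and its limit gives no sign of a gain. Compound 4 is therefore expected to stay at the limit, the step that the limit leaves unreadable from compound 3 to compound 4 being estimated as within the scatter. The estimate for compound 4 is 35000 nM, range 15000 nM to 90000 nM.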

Compound 4, half-maximal inhibitory concentration: > 25000 nM
Compound 4 ended at the assay's limit; the forecaster's own chance of this, stated with the estimate: 85%; the middle value does not contradict the limit.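

In this assay, among the compounds shown here, compound 4 gives > 25000 nM, a limit, so no step from compound 1 or compound 3 can be read. The compounds shown leave open whether chloro in place of hydrogen on an aromatic carbon changes the number at all.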